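This account rests on a few compounds, and the source may have more. Where it says the series, first, only, none or still open, it means among the compounds named here.

Compound 3 `COc1cc2ncnc(NCc3cccc(NC(=O)Nc4ccc(C)cc4)c3)c2cc1OC` is one of three measured analogues sharing a common core, and in a functional assay on HepG2 cells (Homo sapiens) for antiproliferative activity, read by MTT assay (on this read-out higher numbers stand for weaker inhibition and lower numbers for stronger inhibition), compound 3 gives only a limit, > 50000 nM. Compound 1 `COc1cc2ncnc(NCc3cccc(NC(=O)Nc4ccccc4)c3)c2cc1OC` gives 19700 nM. Compound 2 `COc1cc2ncnc(NCc3cccc(NC(=O)Nc4ccccc4C)c3)c2cc1OC` likewise reaches only a limit, > 50000 nM. Adding a methyl weakens inhibition in both measured cases: an at least 2.5-fold higher number from compound 1 to compound 2 (0.40 log units; beyond the scatter) and an at least 2.5-fold higher number from compound 1 to compound 3 (0.40 log units; beyond the scatter), while a step that the two limits leave unreadable from compound 2 to compound 3 because of the limit of > 50000 nM in this assay, at which 2 of the 3 values shown sit. The next compound, compound 4 `COc1ccccc1NC(=O)Nc1cccc(CNc2ncnc3cc(OC)c(OC)cc23)c1`, carries 2-methoxyphenyl in place of 4-methylphenyl on an amide-type nitrogen. Among the measured compounds shown here, no measured step swaps a methyl for a methoxy, but both measured methyl additions pushed the number past the limit, so only a small step is expected, an at least 1.2-fold lower number from compound 3 to compound 4 (0.09 log units; that floor lies within the scatter), and compound 4 is estimated at 40000 nM, plausibly between 10000 nM and 120000 nM.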

Compound 4, half-maximal inhibitory concentration: 27200 nM
For compound 4 the middle estimate is 1.5-fold (0.17 log units) above the measured one, and the stated range covers the measured number.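

Compound 4 shows that a group added to this phenyl ring need not push the number to the limit, as each methyl did. Methoxy in place of hydrogen gives a 1.4-fold higher number from compound 1 to compound 4 (0.14 log units; within the scatter), so compound 1 and compound 4 cannot be told apart. Methoxy in place of methyl gives an at least 1.8-fold lower number from compound 2 to compound 4 (0.26 log units; that floor lies within the scatter), and 2-methoxyphenyl in place of 4-methylphenyl gives an at least 1.8-fold lower number from compound 3 to compound 4 (0.26 log units; that floor lies within the scatter), though both figures are only floors.

Going by these compounds, what an amine or a carboxylic acid on this ring would do remains open. The true sizes of those two steps also remain open: the limit of > 50000 nM in this assay, at which 2 of the 4 values shown sit.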